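Cyano in place of hydrogen on a diphenylmethoxy carbamate

A few compounds are considered here, and "the series" means these few. Any claim that something is new, unique, unknown or untested is made for them only; others in the source may bear on it.

Measured so far in an assay on membranes from brain for binding affinity to Fatty-acid amide hydrolase 1 (Mus musculus), read by fluorescence, with stated times of 1 h and 30 min; on this read-out higher numbers stand for weaker inhibition and lower numbers for stronger inhibition:
compound 1 `N#Cc1cnn(C(=O)NCc2ccc(OCc3ccccc3)cc2)c1`: 60 nM
compound 2 `Cc1cnn(C(=O)NCc2ccc(OC(c3ccccc3)c3ccccc3)cc2)c1`: > 100000 nM
compound 3 `O=C(NCc1ccc(OC(c2ccccc2)c2ccccc2)cc1)n1cccn1`: > 100000 nM

Compound 3 `O=C(NCc1ccc(OC(c2ccccc2)c2ccccc2)cc1)n1cccn1` gives only a limit of the assay, > 100000 nM, not a number. Compound 2 likewise sits at a limit, > 100000 nM; the step that the two limits leave unreadable from compound 2 to compound 3 therefore cannot be read. Among the measured compounds shown here, only compound 1 yields a number, 60 nM, and it differs from compound 3 in two places, so no single measured step bears on the change now considered.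

Compound 4 `N#Cc1cnn(C(=O)NCc2ccc(OC(c3ccccc3)c3ccccc3)cc2)c1` arises from compound 3 by cyano in place of hydrogen on an aromatic carbon. This is the group that compound 1 also carries, though compound 1 bears the benzyloxy rather than the diphenylmethoxy side chain. Compound 2, with methyl at the same position and the diphenylmethoxy side chain, stands at the limit (the limit of > 100000 nM in this assay, at which 2 of the 3 values shown sit), as does compound 3, so the direction and size of the step to compound 4 cannot be inferred from any measured pair. For compound 4 the value is expected to be 10000 nM, between 300 nM and 200000 nM, which means an estimated step of an at least 10-fold lower number from compound 3 to compound 4 (1.00 log units; beyond the scatter) toward stronger inhibition, with a real chance that the assay again reports only a limit.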

Compound 4, half-maximal inhibitory concentration: > 100000 nM
Compound 4: only a limit was reported (the forecaster's own chance of this, stated with the estimate: 45%); middle value at least 10-fold (1.00 log units) from the limit.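

With the diphenylmethoxy side chain, the cyano group that compound 1 also carries does not bring a numerical reading in this assay: compound 4 stands at a limit of the assay, > 100000 nM. Phenyl in place of hydrogen on the saturated chain carbon bound to an aromatic carbon and an oxygen on an aromatic ring gives the one readable step, an at least 1600-fold higher number from compound 1 to compound 4 (3.22 log units; beyond the scatter), toward weaker inhibition, so the same cyano group is compatible with a measured value on the benzyloxy side chain but not on the diphenylmethoxy one. The steps to compound 4 from compound 2 and compound 3 cannot be read, which leaves hydrogen, methyl and cyano at this ring position unranked with the diphenylmethoxy side chain: the limit of > 100000 nM in this assay, at which 3 of the 4 values shown sit.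

As far as these compounds go, whether an amine or a carboxylic acid at this position would bring the diphenylmethoxy series to a readable value stays open. Also open is how much the cyano group contributes in compound 1, as the compounds shown offer no benzyloxy partner carrying hydrogen at this position.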